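Fluoro on the chloropyridine of compound 2

The source may report more compounds than this note shows. Statements on the series, on what has been measured and on what is new or still open speak of the compounds shown alone.

Within the data shown here, in an ADME assay on the whole organism (strain Zucker) for pharmacokinetics, with Rattus norvegicus as the target, with stated times of 24 h and 14 days, at a dose of 3 mg/kg by the oral route (a higher number here means more compound in the circulation at the dose given, a lower number less compound in the circulation), compound 2 (`Cn1c(COc2cccc(C(=O)O)c2)nc2ccc(Oc3ccc(Cl)cn3)cc21`) gives 1010 ng.h/mL as the lower of two numbers so far. Compound 1 (`Cn1c(COc2cccc(C(=O)O)c2)nc2ccc(Oc3ccc4c(c3)OCC4)nc21`) gives 3390 ng.h/mL there. The gap between these two compounds lies beyond the scatter. Compound 3 (`Cn1c(COc2cccc(C(=O)O)c2)nc2ccc(Oc3ncc(Cl)cc3F)cc21`) has fluoro in place of hydrogen on an aromatic carbon and so turns 5-chloropyridin-2-yl into 5-chloro-3-fluoropyridin-2-yl. Among the measured compounds shown here, no measured pair shows this change, so only a small rise in this assay is expected, perhaps none beyond the scatter. The estimated step is a 1.4-fold higher number from compound 2 to compound 3 (0.14 log units; within the scatter) and stays modest. Compound 3 is estimated at 1400 ng.h/mL (550 ng.h/mL to 3600 ng.h/mL).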

Compound 3, area under the concentration-time curve: 3910 ng.h/mL
Beside the measured number, compound 3's estimate is 2.8-fold (0.45 log units) below it, outside the stated range (above it).
By their numbers in this assay, from the lowest: compound 2; then compounds 1 and 3 (each within the scatter of the next).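

In this assay fluoro in place of hydrogen on an aromatic carbon, ortho to a large group and two atoms from the ring nitrogen, gives a 3.9-fold higher number from compound 2 to compound 3 (0.59 log units; beyond the scatter) and so is a change that registers at this position. This one heavy atom, with the rest of the structure unchanged, is enough for a step beyond the scatter. Nothing available bears on why the number rises.

As far as these compounds go, whether a methyl or methoxy group on the same carbon gives a comparable step remains open. So does whether fluoro has any such effect elsewhere on the chloropyridine.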